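The source may report more compounds than this note shows. Statements on the series, on what has been measured and on what is new or still open speak of the compounds shown alone.

Measured so far in a functional assay on the whole organism for antagonist activity, with Mus musculus as the target; a lower number here means that less compound is needed, a higher number that more compound is needed for the effect:
- compound 1, `COc1cc(N)c(Cl)cc1NC(=O)C1CCN(C2CCCC2)CC1`: > 10 mg/kg
- compound 2, `COc1ccc(CN2CCC(C(=O)Nc3cc(Cl)c(N)cc3OC)CC2)cc1`: 0.9 mg/kg
- compound 3, `CCC(CC)CN1CCC(C(=O)Nc2cc(Cl)c(N)cc2OC)CC1`: > 10 mg/kg

The value recorded for compound 1 is a limit of this assay, not a number. The value recorded for compound 3 is likewise a limit, so compound 3 stands at the limit of > 10 mg/kg in this assay, at which 2 of the 3 values shown sit, and its true position is not read. Among the compounds with values here, compound 2 is the only member of the series with a measured number.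

Within the data shown here, two measured steps bear on the change under study. The step of an at least 11-fold lower number from compound 1 to compound 2 (1.04 log units; beyond the scatter) shows that a benzyl-type group on the ring nitrogen gives a far lower number than cyclopentyl. The step of an at least 11-fold higher number from compound 2 to compound 3 (1.04 log units; beyond the scatter) shows the reverse: replacing the aryl by a branched alkyl pushes the value back to the limit. The step that the two limits leave unreadable from compound 1 to compound 3 between the two limits adds nothing readable.

Compound 4, `COc1cc(N)c(Cl)cc1NC(=O)C1CCN(Cc2cccc(Cl)c2)CC1`, differs from compound 3 as follows: 3-chlorophenyl in place of pentan-3-yl on a saturated chain carbon bound to an amine nitrogen in a ring. This brings the series back from a branched alkyl to an aryl-bearing benzyl group, the direction that in the step of an at least 11-fold higher number from compound 2 to compound 3 (1.04 log units; beyond the scatter) was associated with the large change. A large step toward a lower number is therefore expected for an at least 6.6-fold lower number from compound 3 to compound 4 (0.82 log units; beyond the scatter), returning compound 4 into the region occupied by compound 2. Compound 4 is estimated at 1.5 mg/kg, with a range from 0.4 mg/kg to 6 mg/kg.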

Compound 4, dose for half-maximal effect: > 4 mg/kg
Compound 4: no number, only a limit; the forecaster's own chance of this, stated with the estimate: 15%; middle value at least 2.6-fold (0.42 log units) away from the limit.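

In this assay compound 4 carries a limit and not a number: the limit of > 4 mg/kg in this assay, at which 1 of the 4 values shown sits.

Within the data shown here, the one readable step, an at least 4.4-fold higher number from compound 2 to compound 4 (0.64 log units; beyond the scatter), lies beyond the scatter and shows that the position is sensitive to the aryl group itself: 3-chlorophenyl in place of 4-methoxyphenyl on the saturated chain carbon bound to the amine nitrogen in the ring does not keep the series at the level of compound 2, whereas the steps from compound 1 and from compound 3 to compound 4 cannot be read. An aryl group on this carbon is therefore not enough by itself for a low number, and compound 4 goes against the simple reading of aryl against alkyl that compound 1, compound 2 and compound 3 allowed.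

Among these compounds, compound 2 remains the only member of the series with a measured number, and the true place of compound 4 relative to compound 1 and compound 3 stays unread. Still open, as far as these compounds go, is whether the difference follows the methoxy group, the chlorine or the place of the substituent on the ring, and how an unsubstituted benzyl group or a pyridylmethyl group on the ring nitrogen would read.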